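Removing a methyl from an indole nitrogen in chalcone analogues

The source may report more compounds than this note shows. Statements on the series, on what has been measured and on what is new or still open speak of the compounds shown alone.

Measured so far in a functional assay on A2780 cells (Homo sapiens) for antiproliferative activity, read by MTT assay, with a stated time of 48 h; on this read-out lower numbers stand for stronger inhibition and higher numbers for weaker inhibition:
- Compound 1 `COc1ccc2c(/C=C/C(=O)c3cc(OC)c(OC)c([N+](=O)[O-])c3)c[nH]c2c1` gives 742 nM
- Compound 2 `COc1cc(C(=O)/C=C/c2cn(C)c3ccccc23)cc(N)c1OC` gives 441 nM
- Compound 3 `COc1ccc2c(/C=C/C(=O)c3cc(OC)c(OC)c([N+](=O)[O-])c3)cn(C)c2c1` gives 952 nM

Compound 1 and compound 3 share a core and differ in one place: hydrogen in place of methyl on an aromatic nitrogen. In this assay this change made a step of a 1.3-fold lower number from compound 3 to compound 1 (0.11 log units; within the scatter), so the two compounds cannot be told apart with confidence.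

Compound 2 carries a different core; the difference between the core of compound 2 and the core of compound 3 is not broken down here. Compound 4 `COc1cc(C(=O)/C=C/c2c[nH]c3ccccc23)cc(N)c1OC` is not yet measured. It stands to compound 2 as compound 1 stands to compound 3, with the same change in the same place: hydrogen in place of methyl on an aromatic nitrogen.

Because the earlier step from compound 3 to compound 1 was a 1.3-fold lower number from compound 3 to compound 1 (0.11 log units; within the scatter), the step from compound 2 to compound 4 is expected to be small as well, about a 1.3-fold lower number from compound 2 to compound 4 (0.10 log units; within the scatter), which rests on a single precedent. Compound 4 is therefore estimated at 350 nM, with a likely range from 180 nM to 750 nM.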

Compound 4, half-maximal inhibitory concentration: 351 nM
For compound 4 the middle estimate is 1.0-fold (0.00 log units) below the measured one, within the range that was stated.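

In this assay, putting hydrogen in place of the methyl on the aromatic nitrogen gave a 1.3-fold lower number from compound 2 to compound 4 (0.10 log units; within the scatter), so this pair, like the earlier one, cannot be told apart with confidence. Set side by side, the two steps agree, and the change carried over from one core to the other without any visible difference: the same change on two cores in this assay, a 1.3-fold lower number (0.11 log units; within the scatter) from compound 3 to compound 1 and a 1.3-fold lower number (0.10 log units; within the scatter) from compound 2 to compound 4, 1.0-fold (0.01 log units) apart, within the scatter of two such steps This shows that on these two cores, swapping the methyl for hydrogen leaves the number within the usual scatter, but it does not show that the change has any real effect on activity, and two cores are too few to make a rule for the whole series.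

The compounds shown carry only hydrogen or methyl on this nitrogen, which leaves open what a larger group there, such as an ethyl, a longer chain or an acetyl, would do to the number. They also leave open whether the step would stay this small on other cores or in other cell lines.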